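Working notes: compound 4 set against compound 2

The source may report more compounds than this note shows. Statements on the series, on what has been measured and on what is new or still open speak of the compounds shown alone.

Compound 1 `Cc1cc(S(=O)(=O)N2C(=O)N[C@@H](c3ccccc3)C2C)ccc1NC(=O)c1ccc(N)cc1` in a functional assay on A549 cells (Homo sapiens) for cytotoxicity, read by MTT assay (a lower number here means a stronger inhibitor, a higher number a weaker inhibitor), gives > 10000 nM, which is a limit of the assay.
Compound 2 `Cc1cc(S(=O)(=O)N2C(=O)N[C@@H](c3ccccc3)C2C)ccc1NC(=O)c1ccc([N+](=O)[O-])cc1` in this assay gives > 10000 nM, also a limit.
Compound 3 `CCOC(=O)Nc1ccc(S(=O)(=O)N2C(=O)N[C@@H](c3ccccc3)C2C)cc1C` in this assay gives 5000 nM.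

Compound 2 therefore stands at a limit rather than at a number; (the limit of > 10000 nM in this assay, at which 2 of the 3 values shown sit). The step that the two limits leave unreadable from compound 1 to compound 2 cannot be read, and the step of an at least 2.0-fold lower number from compound 2 to compound 3 (0.30 log units; that floor lies within the scatter) carries only a floor that lies within the scatter. Compound 4 `CC1[C@H](c2ccccc2)NC(=O)N1S(=O)(=O)c1ccc(NC(=O)c2ccc([N+](=O)[O-])cc2)c(Cl)c1` differs from compound 2 by chloro in place of methyl on an aromatic carbon. Within the data shown here, no measured step covers this exchange, and the two steps around compound 2 give no direction beyond the scatter. The step that the limit leaves unreadable from compound 2 to compound 4 is expected to be none beyond the scatter, with a limit again the most likely outcome. Compound 4 is estimated at 12000 nM, in the range 4000 nM to 40000 nM.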

Compound 4, half-maximal inhibitory concentration: > 10000 nM
Compound 4: no number, only a limit (the forecaster's own chance of this, stated with the estimate: 70%); the middle value is on the limit's open side.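

Among these compounds, compound 4 gives > 10000 nM in this assay, which is a limit, as is the result for compound 2, so no step between them can be read. The compounds shown leave open how chloro in place of methyl acts where a number can be read.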